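The source may report more compounds than this note shows. Statements on the series, on what has been measured and on what is new or still open speak of the compounds shown alone.

Compound 2 `COc1ccc(Cc2cc(-c3ccc(OC)cc3)nn(CC(=O)Nc3ccc(Br)cc3)c2=O)cc1` carries a 4-methoxyphenyl group on the shared core. In a functional assay on HL-60 cells (Homo sapiens), read by calcium flux (on this read-out higher numbers stand for an effect only at larger amounts of compound and lower numbers for an effect already at smaller amounts), compound 2 gives > 50000 nM, which is a limit of the assay rather than a number. Compound 1 `COc1ccc(Cc2cc(-c3cccs3)nn(CC(=O)Nc3ccc(Br)cc3)c2=O)cc1` carries thiophen-2-yl at the same spot. In this assay compound 1 gives > 50000 nM, again a limit. Compound 3 `COc1ccc(-c2cc(Cc3cccc(OC)c3)c(=O)n(CC(=O)Nc3ccc(F)cc3)n2)cc1` differs from the other two in more than one place, and in this assay compound 3 gives > 50000 nM, also a limit. For the measured compounds named here, the single step between neighbours, a step that the two limits leave unreadable from compound 1 to compound 2, therefore has no readable size. The whole picture is summed up by the limit of > 50000 nM in this assay, at which 3 of the 3 values shown sit. Compound 4 `COc1ccc(Cc2cc(-c3ccc(Cl)cc3)nn(CC(=O)Nc3ccc(Br)cc3)c2=O)cc1` arises from compound 2 by chloro in place of methoxy on an aromatic carbon. Going by the values given here, no measured step gives a number by which to scale this change, and the three values show only where the assay stops measuring. The step expected here, a number no higher from compound 2 to compound 4 (the limit leaves the size open), amounts to no readable change. For compound 4 the estimate is 50000 nM, with a range from 5000 nM to 200000 nM. Most probably the assay will again report only a limit for compound 4.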

Compound 4, half-maximal effective concentration: > 50000 nM
Compound 4: no number, only a limit; the forecaster's own chance of this, stated with the estimate: 75%; the middle value lies on the limit itself.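

In this assay compound 4 gives > 50000 nM, which is a limit and not a number. The steps from compound 1 and compound 2 to compound 4 therefore cannot be read. The compounds shown leave open whether any change on the shared core would give a measurable value: the limit of > 50000 nM in this assay, at which 4 of the 4 values shown sit.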